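From 2-nitrophenyl to 3,4,5-trimethoxyphenyl on a shared core

A few compounds are considered here, and "the series" means these few. Any claim that something is new, unique, unknown or untested is made for them only; others in the source may bear on it.

Compound 1 `COc1cc2ncnc(Nc3ccc(F)c(Cl)c3)c2cc1NC(=O)/C=C/c1ccccc1[N+](=O)[O-]`: 36500 nM
Compound 2 `O=C(/C=C/c1ccccc1[N+](=O)[O-])Nc1cc2c(Nc3ccc(F)c(Cl)c3)ncnc2cc1O[C@H]1CCOC1`: 28400 nM

Both values come from a functional assay on MCF7 cells (Homo sapiens) for cytotoxicity, read by MTT assay, with a stated time of 72 h; a higher number here means a weaker inhibitor, a lower number a stronger inhibitor. Going by the values given here, compound 1 is one of only two measured compounds, and it cannot be told apart from compound 2: the step is a 1.3-fold lower number from compound 1 to compound 2 (0.11 log units; within the scatter). Compound 1 therefore has no clear rank, and the data show only that the two share the same level.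

The next compound, compound 3 `COc1cc2ncnc(Nc3ccc(F)c(Cl)c3)c2cc1NC(=O)/C=C/c1cc(OC)c(OC)c(OC)c1`, keeps the core of compound 1 and exchanges one group: 3,4,5-trimethoxyphenyl in place of 2-nitrophenyl on a double-bonded chain carbon bound to a double-bonded chain carbon. Both groups hold one six-membered aromatic ring of carbon only.

Among the compounds with values here, the single measured step offers little guidance, since it changes the group on an oxygen on an aromatic ring, a different place. Within the data shown here, no measured pair tests a change on the double-bonded chain carbon. With no evidence for a direction, no step beyond the scatter is expected in this assay, though the uncertainty is wide.

The expected change is a 1.3-fold lower number from compound 1 to compound 3 (0.12 log units; within the scatter).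

For compound 3 the estimated value is 28000 nM, with an expected range from 8000 nM to 80000 nM.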

Compound 3, half-maximal inhibitory concentration: "not active" (no number reported)
Compound 3: no number reported; the estimate stays without a comparison.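

In this assay, going by these compounds alone, compound 3 is reported only as "not active", without a number, so no step from compound 1 to compound 3 can be read. No other measurement bears on this result. As far as these compounds go, it remains open how far 3,4,5-trimethoxyphenyl in place of 2-nitrophenyl moves the number from that of compound 1 (36500 nM).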